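This account rests on a few compounds, and the source may have more. Where it says the series, first, only, none or still open, it means among the compounds named here.

In a functional assay on cells (Melanoma cell, Homo sapiens) for cytotoxicity, with a stated time of 48 h (on this read-out lower numbers stand for stronger inhibition of growth and higher numbers for weaker inhibition of growth), compound 2 `COc1ccc2c(c1)/C(=C\c1cc(OC)c(OC)c(OC)c1)C(=O)N2C` gives 21900 nM and sits within the scatter of compound 1 `COc1cc(/C=C2/C(=O)N(C)c3ccc(O)cc32)cc(OC)c1OC` at 16200 nM on the same read-out. Compound 3 `COc1cc(/C=C2\C(=O)N(Cc3ccc(Cl)cc3)c3ccccc32)cc(OC)c1OC` gives 8900 nM and so lies lower than compound 2 by more than the scatter. Among the compounds with values here, the next compound, compound 4 `COc1ccc(CN2C(=O)/C(=C/c3cc(OC)c(OC)c(OC)c3)c3cc(OC)ccc32)cc1`, has no measurement yet. Its change from compound 2 is 4-methoxyphenyl in place of hydrogen on a saturated chain carbon bound to an amide-type nitrogen in a ring and amounts to 4-methoxyphenyl in place of hydrogen on a saturated chain carbon bound to an amide-type nitrogen in a ring. Within the data shown here, the one measured step of a 1.4-fold higher number from compound 1 to compound 2 (0.13 log units; within the scatter) concerns another place, an oxygen on an aromatic ring, so it offers little guidance here. Compound 3 is the closer guide, since it also carries a larger group with an aromatic ring on that nitrogen. Its value of 8900 nM is lower than that of compound 2, although its structure differs elsewhere too. A modest move towards a lower number is therefore expected in this assay, estimated as a 2.0-fold lower number from compound 2 to compound 4 (0.30 log units; within the scatter) with wide uncertainty. For compound 4 the estimated value is 11000 nM (expected range 4500 nM to 25000 nM).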

Compound 4, concentration for total growth inhibition: 5700 nM
Compound 4: middle estimate off by 1.9-fold (0.29 log units), on the high side, and the stated range covers the measured number.
By their numbers in this assay, from the lowest: compounds 4, 3, 1 and 2 (each within the scatter of the next, the first and the last beyond it).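

In this assay, adding 4-methoxyphenyl on a saturated chain carbon bound to an amide-type nitrogen in a ring, which turns methyl into 4-methoxybenzyl, gives a 3.8-fold lower number from compound 2 to compound 4 (0.58 log units; beyond the scatter). Within the data shown here, this is the first step between compounds differing in one place that goes beyond the scatter, whereas the earlier step on an oxygen on an aromatic ring, a 1.4-fold higher number from compound 1 to compound 2 (0.13 log units; within the scatter), stays within it, so this position can carry a much larger group with a lower number as the result. Nothing available explains why the number falls at this position.

The compounds shown leave open whether the ring or its methoxy group accounts for the step, which a plain benzyl group could help to separate. They also leave open how a longer chain such as butyl, or a chain ending in an amine, would behave at this position.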